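This account rests on a few compounds, and the source may have more. Where it says the series, first, only, none or still open, it means among the compounds named here.

In a functional assay on OVCAR-8 cells (Homo sapiens) (a higher number here means a weaker inhibitor of growth, a lower number a stronger inhibitor of growth), compound 1 (`O=S(=O)(/C=C/c1ccc(Cl)cc1)Cc1ccc(Nc2ncnc3ccccc23)cc1`) sits at a limit of the assay, > 100000 nM. Compound 2 (`O=S(=O)(/C=C/c1ccc(Cl)cc1Cl)Cc1ccc(Nc2ncnc3ccccc23)cc1`) gives 4000 nM, and a chloro in place of hydrogen brings an at least 25-fold lower number from compound 1 to compound 2 (1.39 log units; beyond the scatter). Compound 3 (`O=S(=O)(/C=C/c1ccc(Cl)cc1Cl)Cc1ccc(Nc2ncnc3cc(Cl)ccc23)cc1`) has only a limit, > 100000 nM, which places it at the limit of > 100000 nM in this assay, at which 2 of the 3 values shown sit. A further chloro in place of hydrogen brought an at least 25-fold higher number from compound 2 to compound 3 (1.39 log units; beyond the scatter). Compound 4 (`O=S(=O)(/C=C/c1ccc(F)cc1F)Cc1ccc(Nc2ncnc3cc(Cl)ccc23)cc1`) carries 2,4-difluorophenyl in place of 2,4-dichlorophenyl on a double-bonded chain carbon bound to a double-bonded chain carbon. Both measured steps were large, but neither exchanges one halogen for another, so they bear on this change only indirectly. Compound 4 keeps the chloro gained in an at least 25-fold higher number from compound 2 to compound 3 (1.39 log units; beyond the scatter), so it is expected to stay weak in this assay, with at most a modest move to a lower number. The expected change is an at least 2.5-fold lower number from compound 3 to compound 4 (0.39 log units; beyond the scatter). Compound 4 is estimated at 40000 nM, within an expected range of 5000 nM to 100000 nM.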

Compound 4, concentration for 50% growth inhibition: > 100000 nM
Compound 4 ended at the assay's limit (the forecaster's own chance of this, stated with the estimate: 55%); middle value at least 2.5-fold (0.39 log units) away from the limit.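

Among these compounds, compound 3 and compound 4 both stand at a limit in this assay, so no step between them can be read: the limit of > 100000 nM in this assay, at which 3 of the 4 values shown sit. The compounds shown leave open whether 2,4-difluorophenyl in place of 2,4-dichlorophenyl changes growth inhibition at all.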